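The source may report more compounds than this note shows. Statements on the series, on what has been measured and on what is new or still open speak of the compounds shown alone.

Working notes on the series. Compound 1 `COc1ccc(/C=C/c2cc(OC)cc(OC)c2/C=C/C(=O)c2cccc(Br)c2)cc1` gives 8.1 ug/mL in a functional assay on A549 cells (Homo sapiens) for antiproliferative activity, read by MTT assay, with a stated time of 48 h; on this read-out lower numbers stand for stronger inhibition and higher numbers for weaker inhibition. Among the three measured compounds it stands second highest; compound 2 `CCCCCCOc1ccc(C(=O)/C=C/c2c(/C=C/c3ccc(OC)cc3)cc(OC)cc2OC)cc1` gives 8.4 ug/mL, within the scatter of compound 1, whereas compound 3 `COc1ccc(/C=C/c2cc(OC)cc(OC)c2/C=C/C(=O)c2ccc(C)cc2C)cc1` gives 0.3 ug/mL, far below both. Among the measured compounds shown here, the one step measured at the carbonyl carbon is a 27-fold lower number from compound 1 to compound 3 (1.43 log units; beyond the scatter), showing that exchange of the aryl group on that carbon can move the number a long way.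

Compound 4 `COc1ccc(/C=C/c2cc(OC)cc(OC)c2/C=C/C(=O)c2ccc(-c3ccccc3)cc2)cc1` differs from compound 1 as follows: 4-phenylphenyl in place of 3-bromophenyl on a carbonyl carbon. For the measured compounds named here, no measured step covers this exchange directly; only the step from compound 1 to compound 3 bears on it, and it concerns a different entering group. It shows that the position is sensitive, but not the direction for a 4-phenylphenyl group. A moderate lowering is therefore expected, smaller than that step and with wide uncertainty: compound 4 is estimated to show a 2.3-fold lower number from compound 1 to compound 4 (0.36 log units; beyond the scatter) from compound 1. In this assay compound 4 is expected at 3.5 ug/mL, within a range of 0.8 ug/mL to 15 ug/mL.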

Compound 4, half-maximal inhibitory concentration: 4.6 ug/mL
For compound 4 the middle estimate is 1.3-fold (0.12 log units) below the measured one, within the range that was stated.
By their numbers in this assay, from the lowest: compound 3; then compounds 4, 1 and 2 (each within the scatter of the next).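

In this assay, the step of a 1.8-fold lower number from compound 1 to compound 4 (0.25 log units; within the scatter) is within the scatter, so the larger 4-phenylphenyl group, with its second aromatic ring, does not separate from 3-bromophenyl on the carbonyl carbon. The step of a 15-fold higher number from compound 3 to compound 4 (1.19 log units; beyond the scatter) is large and beyond the scatter, which shows that the low number of compound 3 does not carry over to every replacement of 3-bromophenyl at this place: among the three aryl groups shown on the carbonyl carbon, only 2,4-dimethylphenyl stands apart. The step of a 1.8-fold lower number from compound 2 to compound 4 (0.26 log units; within the scatter) is also within the scatter, so phenyl and hexyloxy on that aromatic carbon are not separated here.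

On these data alone, whether a single methyl group, or an amine or a carboxylic acid, on this aryl ring would reach the number of compound 3 remains open. Nothing shown accounts for the large gap between 2,4-dimethylphenyl and the other two aryl groups.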